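The compounds below may be only part of what the source reports. "The series", "measured", "known", "first", "only" and "open" are said of these compounds alone.

Measured so far in a functional assay on Jurkat cells (Homo sapiens) for inhibition; on this read-out higher numbers stand for weaker inhibition and lower numbers for stronger inhibition:
compound 1, `CC(C)[C@H](NC(=O)COc1cccc2ccccc12)C(=O)N[C@@H](CC(=O)O)C(=O)CSc1nc(-c2ccccc2)no1`: 102000 nM
compound 2, `CC(C)[C@H](NC(=O)COc1cccc2ccccc12)C(=O)N[C@@H](CC(=O)O)C(=O)COc1ccncn1`: > 200000 nM, a limit of the assay and not a number
compound 3, `CC(C)[C@H](NC(=O)COc1cccc2ccccc12)C(=O)N[C@@H](CC(=O)O)C(=O)CSc1nccc(C(F)(F)F)n1`: > 200000 nM, likewise a limit of the assay

For the measured compounds named here, compound 1 holds the only number among the three values shown; the other two sit at the limit of > 200000 nM in this assay, at which 2 of the 3 values shown sit. From compound 1 the two measured steps read an at least 1.9-fold higher number from compound 1 to compound 2 (0.29 log units; that floor lies within the scatter) and an at least 1.9-fold higher number from compound 1 to compound 3 (0.29 log units; that floor lies within the scatter). Between compound 2 and compound 3 the step is a step that the two limits leave unreadable from compound 2 to compound 3.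

Compound 4, `CC(C)[C@H](NC(=O)COc1cccc2ccccc12)C(=O)N[C@@H](CC(=O)O)C(=O)COc1nncc(Cl)c1Cl`, is not yet measured. Against compound 1 the change is (4,5-dichloropyridazin-3-yl)oxy in place of (3-phenyl-1,2,4-oxadiazol-5-yl)sulfanyl on a saturated chain carbon bound to a carbonyl carbon. Both measured steps away from compound 1 exchange the (3-phenyl-1,2,4-oxadiazol-5-yl)sulfanyl group for another ring-bearing group on the same saturated chain carbon bound to a carbonyl carbon, and both run to the limit of this assay, so the step to compound 4 is expected to go toward a higher number, with its size not readable beyond that floor. The expected step is a 2.0-fold higher number from compound 1 to compound 4 (0.29 log units; within the scatter). Compound 4 is estimated at 200000 nM, within 80000 nM to 500000 nM, with a fair chance that only a limit is reported.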

Compound 4, half-maximal inhibitory concentration: > 200000 nM
Compound 4: only a limit was reported; the forecaster's own chance of this, stated with the estimate: 55%; the middle value sits exactly at the limit.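

In this assay the (4,5-dichloropyridazin-3-yl)oxy group on the saturated chain carbon bound to a carbonyl carbon yields only a limit of the assay, not a number, and the step reads an at least 1.9-fold higher number from compound 1 to compound 4 (0.29 log units; that floor lies within the scatter). This adds a third replacement with no readable value, now one with two chlorine atoms on an oxygen-linked ring, and the steps from compound 2 and compound 3 to compound 4 cannot be read, since all three ends are limits. Among the groups shown at this place, only the (3-phenyl-1,2,4-oxadiazol-5-yl)sulfanyl group of compound 1 gives a number, and no compound goes against this, but the series is now dominated by one ceiling: the limit of > 200000 nM in this assay, at which 3 of the 4 values shown sit.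

The compounds shown leave open whether the number of compound 1 goes with its sulfur link, its oxadiazole or its phenyl ring; a (3-phenyl-1,2,4-oxadiazol-5-yl)oxy group or a (3-methyl-1,2,4-oxadiazol-5-yl)sulfanyl group would each separate these in one place. Going by these compounds, how far the three limit compounds lie from compound 1, and whether they differ from one another, also stays unknown.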